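The source may report more compounds than this note shows. Statements on the series, on what has been measured and on what is new or still open speak of the compounds shown alone.

Measured so far in a functional assay on DU-145 cells (Homo sapiens) for antiproliferative activity, read by WST assay, with a stated time of 3 days (on this read-out lower numbers stand for stronger inhibition and higher numbers for weaker inhibition), for the shared core:

- compound 1 `CCN(CC)CCCCOc1c(-c2cc(OC)c(OC)c(OC)c2)oc2ccccc2c1=O` gives 13300 nM
- compound 2 `CCCN(CCC)CCCCCOc1c(-c2cc(OC)c(OC)c(OC)c2)oc2ccccc2c1=O` gives 24200 nM

Among the compounds with values here, compound 2 stands level with compound 1 on these two numbers, the only measured step being a 1.8-fold higher number from compound 1 to compound 2 (0.26 log units; within the scatter) and nothing more.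

Next in line is compound 3 `CCCCN(CCCC)CCCOc1c(-c2cc(OC)c(OC)c(OC)c2)oc2ccccc2c1=O`, which has the same atoms as compound 2, joined differently. dibutylamino in place of 2-(dipropylamino)ethyl on a saturated chain carbon, three bonds along the chain from an oxygen on an aromatic ring is the counted difference: dibutylamino in place of 2-(dipropylamino)ethyl on a saturated chain carbon, three bonds along the chain from an oxygen on an aromatic ring.

Within the data shown here, only one measured step bears on this change. a 1.8-fold higher number from compound 1 to compound 2 (0.26 log units; within the scatter) also alters the amine end of the chain, and it stays small. The data do not yet separate chain length from the size of the groups on the nitrogen, so no direction can be argued with confidence.

In this assay no step beyond the scatter is expected, and the estimated step is a 1.3-fold lower number from compound 2 to compound 3 (0.13 log units; within the scatter) with no firm direction. For compound 3 the estimated value is 18000 nM with an expected range from 7000 nM to 40000 nM for now.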

Compound 3, half-maximal inhibitory concentration: 15700 nM
Compound 3: the middle estimate sits 1.1-fold (0.06 log units) above what was measured; the measured number falls inside the stated range.
By their numbers in this assay, from the lowest: compounds 1, 3 and 2 (each within the scatter of the next).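

In this assay dibutylamino in place of 2-(dipropylamino)ethyl, on a saturated chain carbon, three bonds along the chain from an oxygen on an aromatic ring, gives a 1.5-fold lower number from compound 2 to compound 3 (0.19 log units; within the scatter) and so shows that this rearrangement of the same atoms at the amine end stays within the scatter. At the same place, dibutylamino in place of (diethylamino)methyl gives a 1.2-fold higher number from compound 1 to compound 3 (0.07 log units; within the scatter) and so adds a second small step, leaving compound 1, compound 2 and compound 3 all within the scatter of one another on this read-out. No supporting measurement is available to account for these small steps.

Chain length and the groups on the nitrogen change together across compound 1, compound 2 and compound 3, so the contribution of each cannot be read separately from these numbers. Also open, going by these compounds, is whether a piperidine or morpholine at the chain end, a carboxylic acid in place of the amine, or a much shorter chain would give a step beyond the scatter.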